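From Phenyl to Tert-Butyl on a Kinase Inhibitor Core

This account rests on a few compounds, and the source may have more. Where it says the series, first, only, none or still open, it means among the compounds named here.

Compound 1 `CC(C)n1nc(-c2cc(-c3ccccc3)on2)c2c(N)ncnc21` was examined in an assay on isolated protein for inhibition of proto-oncogene tyrosine-protein kinase receptor Ret (Homo sapiens), read by radiometric assay and 33P incorporation, in the presence of a further agent that is not named here (a lower number here means a stronger inhibitor, a higher number a weaker inhibitor), and gives 190 nM, standing at one end of the two numbers shown, while compound 2 `CCCCCCCn1nc(-c2cc(C3CC3)on2)c2c(N)ncnc21` gives 96 nM, a value within the scatter of compound 1. Compound 3 `CC(C)n1nc(-c2cc(C(C)(C)C)on2)c2c(N)ncnc21` differs from compound 1 by tert-butyl in place of phenyl on an aromatic carbon. Among the compounds with values here, no step between measured compounds isolates this change, so the step is expected to stay modest, estimated as a 1.2-fold higher number from compound 1 to compound 3 (0.06 log units; within the scatter), no further than the scatter. Compound 3 is therefore expected to give about 220 nM, with a range from 70 nM to 700 nM.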

Compound 3, half-maximal inhibitory concentration: 210 nM
For compound 3 the middle estimate is 1.0-fold (0.02 log units) above the measured one; low and high end bracket the measured number.
By their numbers in this assay, from the lowest: compounds 2, 1 and 3 (each within the scatter of the next, the first and the last beyond it).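

In this assay, tert-butyl in place of phenyl on the aromatic carbon next to the ring oxygen gives a 1.1-fold higher number from compound 1 to compound 3 (0.04 log units; within the scatter) and stays within the scatter. At this position, therefore, the six-membered aromatic ring of compound 1 is not needed to keep the number of compound 3 in the same range, since a group with no ring serves as well. No measurement shown here accounts for this. Still open, as far as these compounds go, is whether an amine, a carboxylic acid or a longer chain on this carbon would hold that range.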